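One Ring Stereocentre Inverted: What to Expect for Compound 3

The source may hold more compounds than are shown below. What is called first, only, known or untested is meant among the compounds shown, and "the series" means these compounds.

Compound 1 `O=c1ccn([C@H]2C[C@H](O)[C@@H](CO)S2)c(=O)[nH]1`: 2700 nM
Compound 2 `Cc1cn([C@H]2C[C@H](O)[C@@H](CO)S2)c(=O)[nH]c1=O`: 120 nM

Among the measured compounds shown here, in a functional assay on L1210 cells (Mus musculus) (on this read-out lower numbers stand for stronger inhibition and higher numbers for weaker inhibition), compound 2 gives the lowest of the two numbers measured so far; its nearest neighbour is compound 1, and the only measured step, a 23-fold lower number from compound 1 to compound 2 (1.35 log units; beyond the scatter), comes from a methyl in place of hydrogen on an aromatic carbon. Compound 3 `Cc1cn([C@@H]2C[C@H](O)[C@@H](CO)S2)c(=O)[nH]c1=O` keeps that methyl and differs from compound 2 in configuration only: the two compounds have the same atoms and bonds and differ only in configuration as drawn: 1 of 3 stereo elements differ; a stereocentre at a saturated ring carbon is drawn R in compound 2 and S in compound 3. For the measured compounds named here, no measured step in this set changes a configuration, so nothing measured bears directly on this change, and the size and direction of its effect cannot be read from the two compounds at hand. The estimate for compound 3 rests on compound 2 alone, which gives 120 nM, and it carries a wide range. Compound 3 is expected to show a 25-fold higher number from compound 2 to compound 3 (1.40 log units; beyond the scatter), towards a weaker number. Compound 3 is estimated at 3000 nM, within 300 nM to 30000 nM.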

Compound 3, half-maximal inhibitory concentration: 66000 nM
For compound 3 the middle estimate is 22-fold (1.34 log units) below the measured one; the measured number lies above the stated range.
By their numbers in this assay, from the lowest: compound 2; then compound 1; then compound 3.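

In this assay, the ring stereocentre proves to be a sensitive point in this series: inverting it gives a 550-fold higher number from compound 2 to compound 3 (2.74 log units; beyond the scatter), a step larger than the one the methyl gave. The earlier compounds shown here showed only what a change on the aromatic carbon could do, whereas this result shows that the methyl alone does not secure a low number, since compound 3 carries it and still gives the highest number of the three. The step can be assigned to that one stereocentre because nothing else changes, as the structures show: the fact that compounds 2 and 3 differ only in the configuration as drawn.

On these data alone, whether the methyl would have the same effect in the configuration of compound 3 remains open, as does the effect of inverting either of the other two stereo elements. Also open, as far as these compounds go, is how an ethyl group or a bromine atom in place of the methyl would read in this assay.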